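The compounds below may be only part of what the source reports. "The series", "measured", "known", "first", "only" and "open" are said of these compounds alone.

Measured in a functional assay on A498 cells (Homo sapiens) for cytotoxicity, read by sulforhodamine B assay, with a stated time of 48 h, tested at 1 uM; on this read-out lower numbers stand for a stronger effect and higher numbers for a weaker effect at the one concentration tested: compound 1 `COc1cc(C)cc(-c2nn(CC#N)cc2-c2ccc(-c3cccc(C(C)=O)c3)nc2)c1` gives -21%; compound 2 `Cc1cc(O)cc(-c2nn(CC#N)cc2-c2ccnc(-c3ccc(Oc4ccccc4)cc3)c2)c1` gives 26%.

Compound 2 thus stands at the highest of the two numbers in this assay, a number well above that of compound 1, a gap beyond the usual scatter. Compound 3 `Cc1cc(O)cc(-c2nn(CC#N)cc2-c2ccnc(-c3ccc(N(C)C)cc3)c2)c1` differs from compound 2 in one place: dimethylamino in place of phenoxy on an aromatic carbon. Within the data shown here, no measured pair shows this change, so the size of its step is unknown. The step from a number 6 percentage points lower from compound 2 to compound 3 (within the scatter) is expected to stay within the usual scatter, with no clear direction. For compound 3 the estimated value in this assay is 20%, with a range from -20% to 50%.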

Compound 3, a percentage reported as activity, at one concentration (the size of the read-out at that concentration, not a potency): 5%
Estimate against measurement, compound 3: 15 percentage points above; the measured number falls inside the stated range.
By their numbers in this assay, from the lowest: compound 1; then compound 3; then compound 2.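

Among these compounds, replacing phenoxy with dimethylamino on this aromatic carbon, para to a large group, gives the first measured step at this position in this assay, a number a number 21 percentage points lower from compound 2 to compound 3 (beyond the scatter). The read-out thus responds to the group placed here, and the smaller dimethylamino, which has no ring, gives the stronger effect of this pair. No available evidence bears on the reason for this step. The compounds shown leave open whether the step goes with the loss of the ring or with the entering nitrogen. They also leave open how a methoxy group or a primary amine on the same carbon would read.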